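The source may report more compounds than this note shows. Statements on the series, on what has been measured and on what is new or still open speak of the compounds shown alone.

Working notes on a series built on one shared core. Compound 1 `CCOC(=O)N1N=C(c2ccccc2)NN=C1c1ccccc1` is the ethyl ester of that core. In a functional assay on A549 cells (Homo sapiens) for antiproliferative activity, read by sulforhodamine B assay (on this read-out higher numbers stand for weaker inhibition and lower numbers for stronger inhibition), compound 1 gives only a limit, > 100000 nM, with no single number among its entries. Compound 2 `CCCCCOC(=O)N1N=C(c2ccccc2)NN=C1c1ccccc1`, the pentyl ester, gives in this assay 40800 nM; 40800 nM (2 entries). Compound 3 `CC(C)CCOC(=O)N1N=C(c2ccccc2)NN=C1c1ccccc1`, the isopentyl ester, gives in this assay 44200 nM; 44200 nM (2 entries). The numbers for compound 2 and compound 3 lie within the usual scatter of each other, so no order can be read between them. Where compound 1 stands is set by the limit of > 100000 nM in this assay, at which 1 of the 3 values shown sits; it is the one member of the set without a number.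

Compound 4 `O=C(OCCCl)N1N=C(c2ccccc2)NN=C1c1ccccc1` is the next member and is not yet measured in this assay. Against compound 1 the change is chloro in place of hydrogen on a saturated chain carbon, two bonds along the chain from an oxygen next to a carbonyl group, which read one bond further out is ethyl to 2-chloroethyl. Among the compounds with values here, no step between measured compounds covers this change, and the longer esters of compound 2 and compound 3 only show that a number is reachable on this core. The step expected in this assay is an at least 1.2-fold lower number from compound 1 to compound 4 (0.09 log units; that floor lies within the scatter), that is none beyond the scatter. The estimate for compound 4 in this assay is 80000 nM, in a range from 30000 nM to 250000 nM, with a fair chance that again only a limit is returned.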

Compound 4, half-maximal inhibitory concentration: 101000 nM
Compound 4: middle estimate off by 1.3-fold (0.10 log units), on the low side; the measured number falls inside the stated range.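

No new step can be read from compound 1 to compound 4 in this assay, because one end of this pair is a limit and not a number: the limit of > 100000 nM in this assay, at which 1 of the 4 values shown sits.

The compounds shown leave open whether ethyl to 2-chloroethyl moves the number in this assay at all, and what chloro in place of hydrogen would do on the longer esters of compound 2 and compound 3.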